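This account rests on a few compounds, and the source may have more. Where it says the series, first, only, none or still open, it means among the compounds named here.

Measured compounds:
Compound 1, `Oc1cccc(-c2cc(-c3ccc(Cl)cc3)nc(-c3cccnc3)c2)c1`, 16800 nM
Compound 2, `Oc1cccc(-c2cc(-c3ccc(Cl)cc3)nc(-c3ccccn3)c2)c1`, 13500 nM
Compound 3, `Oc1cccc(-c2cc(-c3ccccc3)nc(-c3ccc(Cl)cc3)c2)c1`, 8110 nM

All three values come from a functional assay on HCT-15 cells (Homo sapiens) for cytotoxicity, read by CCK-8 assay and cell counting, with a stated time of 2 days; on this read-out higher numbers stand for weaker inhibition and lower numbers for stronger inhibition. Compound 3 stands lowest of the three numbers: its number lies below that of compound 2 by a 1.7-fold lower number from compound 2 to compound 3 (0.22 log units; within the scatter), which is within the scatter, and below that of compound 1 by a 2.1-fold lower number from compound 1 to compound 3 (0.32 log units; beyond the scatter), which is beyond it.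

Compound 4, `Oc1cccc(-c2cc(-c3ccc(Cl)cc3)nc(-c3ccco3)c2)c1`, has not yet been measured in this assay. It differs from compound 3 in one place: furan-2-yl in place of phenyl on an aromatic carbon. The group enters on an aromatic carbon of the shared core, next to the ring nitrogen, meta to a 3-hydroxyphenyl group and meta to a 4-chlorophenyl group.

Among the measured compounds shown here, two measured steps bear on this change, both at the same place in the shared core: a 2.1-fold lower number from compound 1 to compound 3 (0.32 log units; beyond the scatter) and a 1.7-fold lower number from compound 2 to compound 3 (0.22 log units; within the scatter). In both, phenyl replaced a pyridinyl group and the number fell, modestly in one case and within the scatter in the other. Compound 4 runs the other way, putting furan-2-yl in place of phenyl. A step of comparable size in the reverse direction is therefore expected, at most modest and possibly within the scatter, so compound 4 is estimated at 12000 nM, with a range from 5000 nM to 30000 nM. The expected step is a 1.5-fold higher number from compound 3 to compound 4 (0.17 log units; within the scatter).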

Compound 4, half-maximal inhibitory concentration: 10200 nM
Compound 4: the middle estimate sits 1.2-fold (0.07 log units) above what was measured; the range from low to high includes it.
By their numbers in this assay, from the lowest: compounds 3, 4, 2 and 1 (each within the scatter of the next, the first and the last beyond it).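

In this assay, among the compounds shown here, furan-2-yl puts a five-membered aromatic ring with an oxygen at this position, a ring type the earlier compounds did not show, and the change from phenyl stays within the scatter: a 1.3-fold higher number from compound 3 to compound 4 (0.10 log units; within the scatter). The comparisons with the two pyridinyl groups also stay within the scatter, at a 1.3-fold lower number from compound 2 to compound 4 (0.12 log units; within the scatter) and a 1.6-fold lower number from compound 1 to compound 4 (0.22 log units; within the scatter), so compound 4 cannot be separated from any of the other three compounds. The position therefore accepts a smaller ring with a different hetero atom without a change that this assay can resolve, although compound 1 and compound 3 remain separated beyond the scatter. Nothing available explains why these ring exchanges have so little effect on the number.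

Every group shown at this position is an aromatic ring, so it remains open whether an amine, a carboxylic acid or a longer alkyl chain there would move the number beyond the scatter. Also open, on these data alone, is whether the result would hold without the 3-hydroxyphenyl group, which all four compounds carry.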